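The source may hold more compounds than are shown below. What is called first, only, known or untested is meant among the compounds shown, and "the series" means these compounds.

Compound 1 `C[C@@H](NC(=O)c1cnc(C#Cc2cccc(F)c2)cn1)C(C)(C)O` gives 64.4%. Compound 2 `C[C@@H](NC(=O)c1ccc(C#Cc2cccc(F)c2)cn1)C(C)(C)C` gives 66%. Compound 3 `CC(C)[C@@H](C)NC(=O)c1ccc(C#Cc2cccc(F)c2)cn1` gives 69.3%.

In a functional assay on HEK293 cells for positive allosteric modulation of metabotropic glutamate receptor 5 (Rattus norvegicus), read by fluorescence and calcium flux (on this read-out lower numbers stand for smaller maximal responses and higher numbers for larger maximal responses), compound 3 carries the highest of the three numbers, yet its gaps to compound 2 and to compound 1 both lie within the scatter, so the three compounds cannot be told apart on this read-out. Compound 4 `CCCNC(=O)c1ccc(C#Cc2cccc(F)c2)cn1` differs from compound 3 by propyl in place of 1,2-dimethylpropyl on an amide-type nitrogen. Going by the values given here, the only measured step of a related kind, a number 3.3 percentage points higher from compound 2 to compound 3 (within the scatter), shortened the chain on the amide nitrogen without moving the number beyond the scatter. The change to propyl goes further than that step, but nothing measured points away from the shared level, so compound 4 is expected to show a number 3.3 percentage points lower from compound 3 to compound 4 (within the scatter), no step beyond the scatter. Compound 4 is therefore estimated at 66%, between 52% and 80%.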

Compound 4, largest response reached (reported as efficacy), in percent of the reference or control that the assay uses: 65.9%
Estimate against measurement, compound 4: 0.1 percentage points above; low and high end bracket the measured number.
By their numbers in this assay, from the lowest: compounds 1, 4, 2 and 3 (each within the scatter of the next).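

Putting propyl on the amide-type nitrogen leaves the response in this assay at the level of the branched chains: the change gives a number 3.4 percentage points lower from compound 3 to compound 4 (within the scatter), and replacing 1,2,2-trimethylpropyl gives a number 0.1 percentage points lower from compound 2 to compound 4 (within the scatter). Among these compounds, neither the branching nor the defined stereocentre of the departing chains is needed to keep this maximal response. No available data give a reason for this flat result. The compounds shown leave open what a cyclohexyl ring, a chain carrying an amine or a carboxylic acid, or a chain longer than propyl would do on this nitrogen.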